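Ring contraction on the amide nitrogen of compound 2

The source may report more compounds than this note shows. Statements on the series, on what has been measured and on what is new or still open speak of the compounds shown alone.

Compound 2 `N=c1oc2ccc(Br)cc2cc1C(=O)NC1CCCCC1` gives 5% in an assay on CHO cells for displacement of a labelled ligand from adenosine receptor A1 (Homo sapiens), read by scintillation counting, with a stated time of 60 min, tested at 10 uM; a lower number here means less inhibition, a higher number more inhibition at the concentration tested (going by the name of the read-out); of the three numbers shown, none is separated from it by more than the scatter, as compound 3 `CCC(CO)NC(=O)c1cc2cc(Cl)ccc2oc1=N` gives 7% and compound 1 `N=c1oc2ccc(Br)cc2cc1C(=O)NCC(O)CO` gives 11%. Going by the values given here, the only single-place step measured, a number 6 percentage points lower from compound 1 to compound 2 (within the scatter), cyclohexyl in place of 2,3-dihydroxypropyl on an amide-type nitrogen, stays within the scatter. Compound 4 `N=c1oc2ccc(Br)cc2cc1C(=O)NC1CCCC1` differs from compound 2 by cyclopentyl in place of cyclohexyl on an amide-type nitrogen. Among the compounds with values here, no measured step covers such a ring contraction; the one step at this nitrogen, a number 6 percentage points lower from compound 1 to compound 2 (within the scatter), shows only that a change there has not moved the read-out beyond the scatter. Compound 4 is therefore expected to show a number 1 percentage points higher from compound 2 to compound 4 (within the scatter), nothing beyond the scatter. The estimate for compound 4 is 6%, with a range from -5% to 17%.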

Compound 4, a percentage reported as inhibition, at one concentration (the size of the read-out at that concentration, not a potency): 17%
The estimate for compound 4 lay 11 percentage points below the measured number, and the stated range covers the measured number.
By their numbers in this assay, from the lowest: compounds 2, 3, 1 and 4 (each within the scatter of the next, the first and the last beyond it).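

In this assay the amide-type nitrogen now shows its first step beyond the scatter, a number 12 percentage points higher from compound 2 to compound 4 (beyond the scatter), a modest change with cyclopentyl in place of cyclohexyl. The step from the open chain stays within the scatter, a number 6 percentage points higher from compound 1 to compound 4 (within the scatter), so cyclopentyl and 2,3-dihydroxypropyl are not separated at this position. Nothing available explains the effect of the ring contraction. From the compounds shown here alone, whether the step continues with cyclobutyl, or what an amine or a carboxylic acid on the ring would give, stays open. All these readings come from one concentration and give no potency.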